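Removing the methoxy group from the benzamide in a thiosemicarbazide series

This account rests on a few compounds, and the source may have more. Where it says the series, first, only, none or still open, it means among the compounds named here.

Measured compounds:
- Compound 1, `O=C(NC(=S)NNc1ncnc2ccccc12)c1ccc(C(F)(F)F)cc1`, gives 7920 nM.
- Compound 2, `COc1ccccc1C(=O)NC(=S)NNc1ncnc2ccccc12`, gives > 50000 nM.
- Compound 3, `COc1cc2ncnc(NNC(=S)NC(=O)c3ccc(Cl)cc3)c2cc1OC`, gives 4590 nM.

All three were tested in a functional assay on KB cells (Homo sapiens) for cytotoxicity, read by MTT assay, with a stated time of 72 h; on this read-out higher numbers stand for weaker inhibition and lower numbers for stronger inhibition. Within the data shown here, compound 2 is the one compound whose result is only a limit, (the limit of > 50000 nM in this assay, at which 1 of the 3 values shown sits), so no number is known for it; it falls outside the range where compounds 1 and 3 were read. Compounds 1 and 3 both carry a single substituent on the benzamide ring and their two values stand within the same region.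

Compound 4, `O=C(NC(=S)NNc1ncnc2ccccc12)c1ccccc1`, has not yet been tested. It differs from compound 2 by hydrogen in place of methoxy on an aromatic carbon. With compound 2 known only as a limit, the size of the step cannot be measured, but since compounds 1 and 3 with other benzamide substituents gave numbers, compound 4 is expected to return a number, and the step of an at least 3.3-fold lower number from compound 2 to compound 4 (0.52 log units; beyond the scatter) is expected to go toward stronger inhibition, beyond the scatter. For compound 4 the expected value is 15000 nM, with a range from 4000 nM to 60000 nM.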

Compound 4, half-maximal inhibitory concentration: 2330 nM
Beside the measured number, compound 4's estimate is 6.4-fold (0.81 log units) above it; measured number below the stated range.
By their numbers in this assay, from the lowest: compounds 4, 3 and 1 (each within the scatter of the next, the first and the last beyond it). At a limit, above all of these: compound 2.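

In this assay, hydrogen in place of methoxy, on an aromatic carbon ortho to a large group, gives an at least 21-fold lower number from compound 2 to compound 4 (1.33 log units; beyond the scatter), so this is a large step and the plain phenyl ring alone is enough to give a readable number. Compound 2 gives only a limit, not a number: the limit of > 50000 nM in this assay, at which 1 of the 4 values shown sits. Hydrogen in place of trifluoromethyl also gives a step beyond the scatter, a 3.4-fold lower number from compound 1 to compound 4 (0.53 log units; beyond the scatter), so in both pairs that can be compared, the ring without a substituent gives the lower number.

From the compounds shown here alone, the exact size of the methoxy step stays unknown, with a limit on one side of it. Going by these compounds, whether the loss belongs to methoxy itself or would follow any group at this position stays open, and a methyl or a hydroxyl group at the same place would help to separate the two.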